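A Naphthalene Replaces a Methoxyphenyl in a Cytotoxic Series

A few compounds are considered here, and "the series" means these few. Any claim that something is new, unique, unknown or untested is made for them only; others in the source may bear on it.

Compound 1 `COc1ccc(-c2ccc3[nH]c(-c4ccc5[nH]c(-c6ccc7[nH]cnc7c6)nc5c4)nc3c2)cc1` gives 90 nM in a functional assay on RPMI 8402 cells (Homo sapiens) for cytotoxicity; on this read-out lower numbers stand for stronger inhibition and higher numbers for weaker inhibition.
Compound 2 `CCCc1nc2cc(-c3nc4cc(-c5nc6cc(-c7ccccc7)ccc6[nH]5)ccc4[nH]3)ccc2[nH]1` gives 60 nM in this assay.

Compound 1 holds the higher of these two numbers, but compound 2 lies within the usual scatter of it, so the pair cannot be told apart. Compound 3 `c1ccc2c(-c3ccc4[nH]c(-c5ccc6[nH]c(-c7ccc8[nH]cnc8c7)nc6c5)nc4c3)cccc2c1` differs from compound 1 in one place: naphthalen-1-yl in place of 4-methoxyphenyl on an aromatic carbon. For the measured compounds named here, no measured pair shows this change. Given how close compound 1 and compound 2 sit, a step of a 1.1-fold lower number from compound 1 to compound 3 (0.05 log units; within the scatter) is expected in this assay, nothing beyond the scatter. Compound 3 is therefore estimated at 80 nM, with a range from 30 nM to 250 nM.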

Compound 3, half-maximal inhibitory concentration: 2100 nM
Estimate against measurement, compound 3: 26-fold (1.42 log units) below, and the stated range ends below it.
By their numbers in this assay, from the lowest: compounds 2 and 1 (each within the scatter of the next); then compound 3.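

Putting naphthalen-1-yl in place of 4-methoxyphenyl on this aromatic carbon gives a 23-fold higher number from compound 1 to compound 3 (1.37 log units; beyond the scatter) in this assay. This position therefore does not accept every aromatic group alike, which the two earlier compounds could not show, as they differ in more than one place. Nothing available accounts for this loss of potency. The compounds shown leave open whether the loss goes with the second aromatic ring entering or with the methoxy group leaving. On these data alone, how a naphthalen-2-yl or a 4-aminophenyl group would fare at this position also remains open.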